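Compound 2 and a naphthalen-2-yl exchange

A few compounds are considered here, and "the series" means these few. Any claim that something is new, unique, unknown or untested is made for them only; others in the source may bear on it.

Compound 1 `O=C1c2ccccc2C(=O)N1CCOC(=S)N(C(=O)c1ccc(F)c(F)c1)c1ccc(Cl)cc1` gives 52000 nM
Compound 2 `O=C1c2ccccc2C(=O)N1CCOC(=S)N(C(=O)c1ccc([N+](=O)[O-])cc1Cl)c1ccc(Cl)cc1` gives 19000 nM

Both values come from an ADME assay on MT4 cells (Homo sapiens) for cytotoxicity, read by MTT assay (a lower number here means that less compound is tolerated, a higher number that more compound is tolerated), and compound 2 holds the lower number of the pair, the gap to compound 1 lying beyond the scatter. Compound 3 `O=C1c2ccccc2C(=O)N1CCOC(=S)N(C(=O)c1ccc2ccccc2c1)c1ccc(Cl)cc1` has not yet been measured. It departs from compound 2 in a single place, with naphthalen-2-yl in place of 2-chloro-4-nitrophenyl on a carbonyl carbon and the rest of the structure shared.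

Going by the values given here, only one measured step bears on this change, an exchange on the same carbonyl carbon, and it shows a 2.7-fold lower number from compound 1 to compound 2 (0.44 log units; beyond the scatter) as a modest move. Among the compounds with values here, no measured compound carries naphthalen-2-yl, so that step offers only a rough guide to size. A step of similar or smaller size is expected in this assay and the expected direction is towards a higher number, resting on compound 2 at 19000 nM being the lower of the two values. The estimated step is a 1.6-fold higher number from compound 2 to compound 3 (0.20 log units; within the scatter) and it may not clear the scatter. Compound 3 is expected at 30000 nM within an estimated range of 13000 nM to 70000 nM for now.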

Compound 3, half-maximal cytotoxic concentration: 37000 nM
Compound 3: the middle estimate sits 1.2-fold (0.09 log units) below what was measured; low and high end bracket the measured number.
By their numbers in this assay, from the lowest: compounds 2, 3 and 1 (each within the scatter of the next, the first and the last beyond it).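

In this assay, a third group on the carbonyl carbon whose other neighbour is the amide-type nitrogen gives a 1.9-fold higher number from compound 2 to compound 3 (0.29 log units; within the scatter) and a 1.4-fold lower number from compound 1 to compound 3 (0.15 log units; within the scatter), so compound 3 lies within the scatter of both earlier compounds, although a 2.7-fold lower number from compound 1 to compound 2 (0.44 log units; beyond the scatter) remains beyond it. Naphthalen-2-yl, with two six-membered aromatic rings of carbon only and no hydrogen-bond acceptors, therefore gives no step beyond the scatter from either 2-chloro-4-nitrophenyl or 3,4-difluorophenyl, and its value cannot be ranked against either of theirs. No available evidence accounts for these differences or for the larger gap between the other two groups.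

As far as these compounds go, all three compounds carry aromatic groups on this carbonyl carbon, so it remains open whether an amine, a carboxylic acid or a longer alkyl chain there would give a number outside the span seen so far. From the compounds shown here alone, it is also open whether these steps would keep their size if the 4-chlorophenyl group on the amide-type nitrogen, which all three compounds share, were exchanged for another group.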